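The source may hold more compounds than are shown below. What is called first, only, known or untested is meant among the compounds shown, and "the series" means these compounds.

Measured so far in a functional assay on U-87MG ATCC cells (Homo sapiens) for cytotoxicity, read by MTT assay, with a stated time of 48 h; a lower number here means a stronger inhibitor, a higher number a weaker inhibitor:

- compound 1 `C/C(=N\NC(=S)Nc1ccccc1I)c1ccccn1` gives 6.1 nM 
- compound 2 `C/C(=N\NC(=S)Nc1ccc(Cl)cc1)c1ccccn1` gives 1.7 nM 
- compound 3 `CC(=NNC(=S)Nc1ccccc1)c1ccccn1` gives 1.4 nM 

Compound 3 sits within the scatter of compound 2, and compound 1 reads a higher number, beyond the scatter from compound 3.

Compound 4 `C/C(=N\NC(=S)Nc1ccccc1)c1ccccn1` comes next, with the two compounds have the same atoms and bonds; at least one stereo element is drawn with a configuration in one of them and without one in the other: 1 of 1 stereo elements differ; a double bond is drawn without a configuration in compound 3 and E in compound 4 as its whole difference from compound 3: the same atoms and bonds, with a double bond drawn without a configuration in compound 3 and E in compound 4. Within the data shown here, no measured pair shows a difference of this kind. The expectation therefore rests on compound 3 at 1.4 nM as the closest reference. The step of a 1.1-fold higher number from compound 3 to compound 4 (0.03 log units; within the scatter) is expected to stay within the scatter, with no clear direction. For compound 4 the estimate is 1.5 nM, with 0.7 nM to 3.5 nM as the expected range.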

Compound 4, half-maximal inhibitory concentration: 1.4 nM
Compound 4: middle estimate off by 1.1-fold (0.03 log units), on the high side; measured number inside the range.
By their numbers in this assay, from the lowest: compounds 3, 4 and 2 (each within the scatter of the next); then compound 1.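

In this assay, there is no change at the digits printed from compound 3 to compound 4 (within the scatter), so the double bond drawn E reads the same as the one drawn without a configuration, and the pair is separated only by how it is drawn: the fact that one of compounds 3 and 4 is drawn with a defined configuration and the other without, at the place where they differ. With E drawn on both sides, hydrogen in place of chloro gives a 1.2-fold lower number from compound 2 to compound 4 (0.08 log units; within the scatter). Hydrogen in place of iodo gives a 4.4-fold lower number from compound 1 to compound 4 (0.64 log units; beyond the scatter), the only one of these steps beyond the scatter.

As far as these compounds go, the reading of the double bond drawn Z remains open. So does the effect of an amine or a carboxylic acid on that aromatic carbon.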